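Working notes: from compound 2 to compound 3

The source may report more compounds than this note shows. Statements on the series, on what has been measured and on what is new or still open speak of the compounds shown alone.

Measured in a functional assay on HepG2 cells (Homo sapiens) for antiproliferative activity, read by spectrophotometry, with a stated time of 2 days; on this read-out lower numbers stand for stronger inhibition of growth and higher numbers for weaker inhibition of growth:
- compound 1 `CC(=O)N1CCN(c2ccc(Nc3ncc(C(F)(F)F)c(N4Cc5cccc(N(C)S(C)(=O)=O)c5C4)n3)cc2)CC1` gives 1400 nM
- compound 2 `Cc1ccc(Nc2ncc(C(F)(F)F)c(N3Cc4cccc(N(C)S(C)(=O)=O)c4C3)n2)cc1C` gives only a limit of the assay, > 30000 nM

Compound 2 has no numerical value, only the limit > 30000 nM. The next compound is compound 3 `COc1cc(Nc2ncc(C(F)(F)F)c(N3Cc4cccc(N(C)S(C)(=O)=O)c4C3)n2)c(OC)cc1Cl`, and the change is 4-chloro-2,5-dimethoxyphenyl in place of 3,4-dimethylphenyl on a nitrogen on an aromatic ring. In words, this is 4-chloro-2,5-dimethoxyphenyl in place of 3,4-dimethylphenyl on a nitrogen on an aromatic ring.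

Going by the values given here, no step between measured compounds is available to size this change. Among the compounds with values here, the one numerical reading, compound 1 at 1400 nM, carries a different group on that nitrogen and gives only a loose guide. A modest move toward stronger growth inhibition is expected in this assay, and another limit would be no surprise. The expected step is an at least 2.1-fold lower number from compound 2 to compound 3 (0.33 log units; beyond the scatter). For compound 3 the estimate is 14000 nM, with an expected range from 3500 nM to 30000 nM.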

Compound 3, concentration for 50% growth inhibition: 25600 nM
For compound 3 the middle estimate is 1.8-fold (0.26 log units) below the measured one, and the stated range covers the measured number.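

In this assay compound 3 gives 25600 nM, a numerical reading for a substituted phenyl on this nitrogen that carries only small groups. Compound 2 gives only a limit of the assay, > 30000 nM. Read against that limit, the change from 3,4-dimethylphenyl to 4-chloro-2,5-dimethoxyphenyl gives an at least 1.1-fold lower number from compound 2 to compound 3 (0.06 log units; that floor lies within the scatter), so its true size stays unresolved: the limit of > 30000 nM in this assay, at which 1 of the 3 values shown sits.

The compounds shown do not separate the chlorine from the two methoxy groups, so a phenyl carrying only one of them would be needed to tell their shares apart. Also open, as far as these compounds go, is whether a phenyl bearing a morpholine or a carboxylic acid on this nitrogen would read closer to compound 1, at 1400 nM, or to compound 3, at 25600 nM.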